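The source may hold more compounds than are shown below. What is called first, only, known or untested is meant among the compounds shown, and "the series" means these compounds.

Compound 1 `NS(=O)(=O)c1ccc(-c2nnc(-c3ccc(F)cc3)o2)cc1` and compound 2 `Cc1ccc(-c2nnc(-c3ccccc3)o2)cc1S(N)(=O)=O` share the same core. In an assay on cells for inhibition of Amine oxidase [flavin-containing] A (Homo sapiens), read by fluorescence and spectrophotometry, using microsomes, with a stated time of 20 min (a higher number here means a weaker inhibitor, a lower number a stronger inhibitor), compound 1 gives 83800 nM. In this assay compound 2 returns only > 100000 nM, which is a limit of the assay and not a number, so compound 2 sits at the limit of > 100000 nM in this assay, at which 1 of the 2 values shown sits. Compound 3 `NS(=O)(=O)c1cc(-c2nnc(-c3ccccc3)o2)ccc1Cl` arises from compound 2 by chloro in place of methyl on an aromatic carbon. Both measured compounds are weak inhibitors, and the step from compound 2 to compound 3 is expected to stay within the usual scatter. Compound 3 is expected to give about 120000 nM, between 40000 nM and 400000 nM. That estimate means a step that the limit leaves unreadable from compound 2 to compound 3.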

Compound 3, half-maximal inhibitory concentration: > 100000 nM
Compound 3 ended at the assay's limit; the forecaster's own chance of this, stated with the estimate: 55%; the middle value lies beyond the limit too.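

Among these compounds, compound 2 and compound 3 both return a limit of the assay and not a number, and no step between them can be read. As far as these compounds go, whether chloro in place of methyl on an aromatic carbon changes inhibition in this assay stays open.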